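This account rests on a few compounds, and the source may have more. Where it says the series, first, only, none or still open, it means among the compounds named here.

Compound 1 `N#Cc1c(N2CCC(c3ccccc3)CC2)ccn(CC2CC2)c1=O`: 309%
Compound 2 `N#Cc1c(N2CCC(c3ccccc3F)CC2)ccn(CC2CC2)c1=O`: 282%
Compound 3 `N#Cc1c(N2CCC(c3cccc(F)c3)CC2)ccn(CC2CC2)c1=O`: 268%

These three compounds were measured in a functional assay on CHO cells for positive allosteric modulation of metabotropic glutamate receptor 2 (Homo sapiens), with a stated time of 30 min; a lower number here means a smaller maximal response, a higher number a larger maximal response. Compound 3 gives the lowest maximal response of the three: a number 14 percentage points lower from compound 2 to compound 3 (beyond the scatter) and a number 41 percentage points lower from compound 1 to compound 3 (beyond the scatter). Compound 4 `N#Cc1c(N2CCC(c3cccc(C(F)(F)F)c3)CC2)ccn(CC2CC2)c1=O` differs from compound 3 in one place: trifluoromethyl in place of fluoro on an aromatic carbon. For the measured compounds named here, no measured step exchanges one group for another at this aromatic carbon, so the step has no direct precedent. The nearest guides are a number 27 percentage points lower from compound 1 to compound 2 (beyond the scatter) and a number 41 percentage points lower from compound 1 to compound 3 (beyond the scatter), where fluoro in place of hydrogen on an aromatic carbon lowered the response each time. A further modest lowering, or no change beyond the scatter, is therefore expected: a number 18 percentage points lower from compound 3 to compound 4 (beyond the scatter). Compound 4 is estimated at 250%, with a range from 200% to 300%.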

Compound 4, largest response reached (Emax), in percent of the reference or control that the assay uses: 191%
Estimate against measurement, compound 4: 59 percentage points above, and the stated range ends above it.
By their numbers in this assay, from the lowest: compound 4; then compound 3; then compound 2; then compound 1.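

At this aromatic carbon the choice of group matters more than the fluoro compounds revealed: in this assay trifluoromethyl in place of fluoro gives a number 77 percentage points lower from compound 3 to compound 4 (beyond the scatter) and is a larger step than either fluoro in place of hydrogen. Measured against the unsubstituted phenyl, trifluoromethyl in place of hydrogen gives a number 118 percentage points lower from compound 1 to compound 4 (beyond the scatter) and is the largest step in this set. Nothing available here explains the size of these drops.

A methyl, a methoxy or a chlorine at this carbon would show whether the drop belongs to trifluoromethyl alone. From the compounds shown here alone, how such groups would rank against fluoro remains open.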